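The source may report more compounds than this note shows. Statements on the series, on what has been measured and on what is new or still open speak of the compounds shown alone.

Measured compounds: compound 1 `Cn1cnnc1-c1cc(Oc2ccc(NC(=O)Nc3cccc(C(F)(F)F)c3)cc2F)ccn1` with 12600 nM; compound 2 `CN(C)CCn1cnnc1-c1cc(Oc2ccc(NC(=O)Nc3ccc(F)c(Cl)c3)cc2F)ccn1` with 7580 nM; compound 3 `CN(C)CCn1cnnc1-c1cc(Oc2ccc(NC(=O)Nc3ccc(Cl)cc3Cl)cc2F)ccn1` with 10400 nM, all in an ADME assay on WI-38 cells (Homo sapiens) for cytotoxicity, read by MTT assay, with a stated time of 72 h; a lower number here means a stronger inhibitor, a higher number a weaker inhibitor.

Compound 1 gives the highest of the three numbers, yet compound 2 and compound 3 lie within the scatter of it. Compound 4 `CCN(CC)CCn1cnnc1-c1cc(Oc2ccc(NC(=O)Nc3cccc(C(F)(F)F)c3)cc2F)ccn1` differs from compound 1 by (diethylamino)methyl in place of hydrogen on a saturated chain carbon bound to an aromatic nitrogen. Going by the values given here, no measured step alters this chain alone. Among the compounds with values here, the one measured step, a 1.4-fold higher number from compound 2 to compound 3 (0.14 log units; within the scatter), changes the aryl group on the urea instead and is within the scatter. Compound 2 and compound 3, which carry a chain with a tertiary amine on this nitrogen, show numbers close to compound 1. A step within the scatter is therefore expected, a 1.3-fold lower number from compound 1 to compound 4 (0.10 log units; within the scatter). Compound 4 is estimated at 10000 nM, between 4000 nM and 25000 nM.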

Compound 4, half-maximal inhibitory concentration: 6920 nM
The estimate for compound 4 lay 1.4-fold (0.16 log units) above the measured number, within the range that was stated.
By their numbers in this assay, from the lowest: compounds 4, 2, 3 and 1 (each within the scatter of the next).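

This is the only pair shown in which the chain on the aromatic nitrogen changes while the aryl group on the urea stays the same. Going from methyl to 2-(diethylamino)ethyl gives a 1.8-fold lower number from compound 1 to compound 4 (0.26 log units; within the scatter) in this assay, so at this position the larger chain with its tertiary amine leaves the reading within the scatter. Nothing measured here bears on the reason for this. Still open, from the compounds shown here alone, is whether a chain ending in a morpholine, a primary amine or a carboxylic acid would also stay within the scatter.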